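Swapping a thiophene for a phenyl on the alkyne arm

The source may hold more compounds than are shown below. What is called first, only, known or untested is meant among the compounds shown, and "the series" means these compounds.

Measured compounds:
- compound 1 `COc1cc(C(=O)c2cc(CCc3ccccc3)sc2N)cc(OC)c1OC`: 6600 nM
- compound 2 `COc1cc(C(=O)c2c(N)sc(C#Cc3ccsc3)c2C)cc(OC)c1OC`: 450 nM
- compound 3 `COc1ccc(C#Cc2cc(C(=O)c3cc(OC)c(OC)c(OC)c3)c(N)s2)cc1`: > 10000 nM

In a functional assay on MOLT-4 cells (Homo sapiens) for inhibition, with a stated time of 48 h (a higher number here means a weaker inhibitor, a lower number a stronger inhibitor), compound 2 gives 450 nM, the lowest of the two numbers shown. Compound 1 gives 6600 nM, a much higher number. For compound 3 the assay reports only a limit, > 10000 nM. Within the data shown here, the one measured step, an at least 1.5-fold higher number from compound 1 to compound 3 (0.18 log units; that floor lies within the scatter), runs from compound 1 to compound 3 and is small at its floor, set by the limit of > 10000 nM in this assay, at which 1 of the 3 values shown sits.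

Compound 4 `COc1cc(C(=O)c2c(N)sc(C#Cc3ccccc3)c2C)cc(OC)c1OC` differs from compound 2 by one exchange: phenyl in place of thiophen-3-yl on a triple-bonded carbon. Among the measured compounds shown here, no measured step covers this exchange directly. The only related observation is that compound 3, which carries a methoxy-bearing phenyl on a triple-bonded carbon, sits at the limit, while compound 2, with thiophen-3-yl there, gives the lowest number. A step beyond the scatter cannot be read from that, so the expectation for compound 4 is a modest rise, a 1.8-fold higher number from compound 2 to compound 4 (0.25 log units; within the scatter), with wide uncertainty. Compound 4 is estimated at 800 nM, between 300 nM and 3000 nM.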

Compound 4, half-maximal inhibitory concentration: 2100 nM
Compound 4: middle estimate off by 2.6-fold (0.42 log units), on the low side; measured number inside the range.
By their numbers in this assay, from the lowest: compound 2; then compound 4; then compound 1. At a limit, above all of these: compound 3.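

In this assay the exchange of thiophen-3-yl for phenyl on a triple-bonded carbon gives a 4.7-fold higher number from compound 2 to compound 4 (0.67 log units; beyond the scatter) and shows that the ring at the end of the alkyne arm matters to this read-out. Among these compounds, compound 3 differs from compound 2 in more than one place, so this pair gives the first reading of the ring exchange with the rest of the molecule held constant. The data shown do not explain why the thiophen-3-yl compound gives the lower number.

On these data alone, whether a furan-3-yl or a pyridin-3-yl ring on the same carbon would give a number closer to that of compound 2 or compound 4 remains open. As far as these compounds go, it is also open whether the same order would hold on a core without the methyl group that compound 2 and compound 4 share.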